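Dropping the Hydroxy Group of Compound 1

The source may hold more compounds than are shown below. What is called first, only, known or untested is meant among the compounds shown, and "the series" means these compounds.

Compound 1 `O=c1[nH]c(=O)n(COC(CO)CO)cc1O` was tested in a functional assay on MCF7 cells (Homo sapiens) for inhibition, read by MTT assay, with a stated time of 72 h; on this read-out lower numbers stand for stronger inhibition and higher numbers for weaker inhibition. In this assay compound 1 reaches only the limit > 100000 nM, which is a limit of the assay and not a number. Compound 2 `Cn1cc(CO)c(N)nc1=O` was run in this assay as well, and compound 2 likewise gives only the limit > 100000 nM. For the measured compounds named here, both results sit at the limit of > 100000 nM in this assay, at which 2 of the 2 values shown sit, so no measured step between compounds exists to draw on.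

Compound 3 `O=c1ccn(COC(CO)CO)c(=O)[nH]1` has not yet been measured. It differs from compound 1 in one place: hydrogen in place of hydroxy on an aromatic carbon. Going by the values given here, with no measured step available, the expected size of this change in this assay rests only on where compound 1 stands. Because compound 1 gives only the limit > 100000 nM, compound 3 is expected to stay at a limit too. The expected step that the limit leaves unreadable from compound 1 to compound 3 is none beyond the scatter. Compound 3 is estimated at 200000 nM, with a range from 60000 nM to 1000000 nM.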

Compound 3, half-maximal inhibitory concentration: > 100000 nM
Compound 3: no number, only a limit; the forecaster's own chance of this, stated with the estimate: 85%; the middle value does not contradict the limit.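

Compound 1 and compound 3 both give only limits in this assay, so the step between them cannot be read: the limit of > 100000 nM in this assay, at which 3 of the 3 values shown sit.

The compounds shown leave open whether hydrogen in place of hydroxy on this aromatic carbon changes inhibition at all.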